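This account rests on a few compounds, and the source may have more. Where it says the series, first, only, none or still open, it means among the compounds named here.

Measured so far:
- Compound 1, `CC(C)[C@H](C[C@H]1OC(=O)NC1=O)c1ccc(-c2ccc3cccc(F)c3c2)[nH]c1=O`, gives 24400 nM in a physicochemical assay for solubility, measured as kinetic solubility, at pH 2; a lower number here means a less soluble compound, a higher number a more soluble compound.
- Compound 2, `C/C(=C1/OC(=O)NC1=O)C(c1ccc(-c2ccc3cccc(F)c3c2)[nH]c1=O)C(C)C`, gives 12700 nM in this assay.
- Compound 3, `CC(C)/C(=C1\C(=O)NC(=O)N1C)c1ccc(-c2ccc3cccc(F)c3c2)[nH]c1=O`, gives 11100 nM in this assay.

Among these three numbers compound 1 has the highest. Its nearest neighbour is compound 2, whose number lies within the usual scatter of such measurements, so no order can be read between compound 1 and compound 2. Compound 3 lies further off, beyond the scatter, so compound 1 does come out more soluble than compound 3.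

Compound 4, `CC(C)[C@@H](c1ccc(-c2ccc3cccc(F)c3c2)[nH]c1=O)[C@@H]1OC(=O)NC1=O`, has not yet been measured in this assay. It differs from compound 1 in one place:

2,4-dioxo-1,3-oxazolidin-5-yl in place of (2,4-dioxo-1,3-oxazolidin-5-yl)methyl on a saturated chain carbon bound to an aromatic carbon and a saturated chain carbon

The shared core stays as it is; what changes is how the 2,4-dioxo-1,3-oxazolidin-5-yl ring is joined to the saturated chain carbon bound to an aromatic carbon and a saturated chain carbon. Going by the values given here, no measured pair shows this exact change, so its effect has to be guessed. The expectation is a step from compound 1 to compound 4 of a 1.1-fold lower number from compound 1 to compound 4 (0.04 log units; within the scatter), which would stay within the scatter rather than point clearly in either direction. For compound 4 the estimate in this assay is therefore 22000 nM, expected to fall between 10000 nM and 45000 nM.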

Compound 4, solubility: 6900 nM
Beside the measured number, compound 4's estimate is 3.2-fold (0.50 log units) above it; the measured number lies below the stated range.
By their numbers in this assay, from the lowest: compounds 4, 3, 2 and 1 (each within the scatter of the next, the first and the last beyond it).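

In this assay, the shared core and the ring stay the same, and the ring's link to the saturated chain carbon bound to an aromatic carbon and a saturated chain carbon is all that changes, yet this gives a 3.5-fold lower number from compound 1 to compound 4 (0.55 log units; beyond the scatter) and lands beyond the scatter. Going by these compounds alone, the earlier compounds offered no pair differing in one place, so this is the first readable sign that the result at this position depends on how the 2,4-dioxo-1,3-oxazolidin-5-yl ring is attached, even with the hydrogen-bond donor and acceptor counts and the net charge of the group unchanged. Nothing available bears on why the number moves.

The compounds shown leave open whether a longer chain between this carbon and the same ring would carry the trend further or reverse it, and how a carboxylic acid or an amine on this carbon would compare with the ring. Within the data shown here, with only one such pair, it also remains open whether the same change would give a step of similar size on a different core.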